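Pyridazine to methylpyridine on the ether of compound 2

The compounds below may be only part of what the source reports. "The series", "measured", "known", "first", "only" and "open" are said of these compounds alone.

Measured compounds:
compound 1 `O=C(O)CCn1c(=O)oc2cc(OCc3ccccc3)c(Cl)cc21`, 1580 nM
compound 2 `C[C@@H](Oc1cc2oc(=O)n(CCC(=O)O)c2cc1Cl)c1cccnn1`, 631 nM
compound 3 `O=C(O)CCn1c(=O)oc2cc(OCc3ccccn3)c(Cl)cc21`, 5010 nM

Values come from an assay on HEK293 cells for inhibition of kynurenine 3-monooxygenase (Homo sapiens), read by LC-MS, with a stated time of 20 h; a lower number here means a stronger inhibitor, a higher number a weaker inhibitor. Compound 2 gives the lowest number of the three: a 2.5-fold lower number from compound 1 to compound 2 (0.40 log units; beyond the scatter), and a 7.9-fold higher number from compound 2 to compound 3 (0.90 log units; beyond the scatter). The change to compound 4 `Cc1cccc([C@@H](C)Oc2cc3oc(=O)n(CCC(=O)O)c3cc2Cl)n1` is 6-methylpyridin-2-yl in place of pyridazin-3-yl on a saturated chain carbon bound to an oxygen on an aromatic ring and a saturated chain carbon. For the measured compounds named here, two measured steps bear on it. The step of a 7.9-fold higher number from compound 2 to compound 3 (0.90 log units; beyond the scatter) replaces the same pyridazin-3-yl ring, though compound 3 also lacks the methyl on the chain carbon; the step of a 3.2-fold higher number from compound 1 to compound 3 (0.50 log units; beyond the scatter) shows pyridin-2-yl in place of phenyl raising the number as well. Both point the same way, so a modest rise beyond the scatter is expected, estimated as a 2.5-fold higher number from compound 2 to compound 4 (0.40 log units; beyond the scatter). Compound 4 is therefore expected to give 1600 nM, with a range of 500 nM to 5000 nM.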

Compound 4, half-maximal inhibitory concentration: 316 nM
Estimate against measurement, compound 4: 5.1-fold (0.70 log units) above; measured number below the stated range.
By their numbers in this assay, from the lowest: compounds 4 and 2 (each within the scatter of the next); then compound 1; then compound 3.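

On the saturated chain carbon, 6-methylpyridin-2-yl stands in place of pyridazin-3-yl with a 2.0-fold lower number from compound 2 to compound 4 (0.30 log units; within the scatter) in this assay, so this assay does not tell the two rings apart here. The rise seen for pyridin-2-yl in place of phenyl, a 3.2-fold higher number from compound 1 to compound 3 (0.50 log units; beyond the scatter), does not carry over to compound 4, which bears a methyl on both the ring and the chain carbon. Nothing measured here accounts for this result. The compounds shown do not separate the ring methyl from the chain methyl, since compound 3 lacks both. Also open, on these data alone, is how 6-ethylpyridin-2-yl or 6-aminopyridin-2-yl would read on that carbon.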